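The compounds below may be only part of what the source reports. "The series", "measured", "known", "first", "only" and "open" are said of these compounds alone.

Working notes on the series. In an in vitro functional assay on HEK293-A cells for agonist activity at metabotropic glutamate receptor 5 (Rattus norvegicus), read by ELISA (a higher number here means a weaker inhibitor, a lower number a stronger inhibitor), compound 1 `CCc1cccc(C#Cc2cccc(C#N)c2)n1` gives 80 nM, compound 2 `CC(=O)c1cccc(C#Cc2cc(F)cc(C#N)c2)n1` gives 240 nM, and compound 3 `CCCCc1cccc(C#Cc2cccc(C#N)c2)n1` gives 700 nM. Compound 3 thus has the highest number of the three: compound 2 sits nearest to it, compound 1 furthest, both gaps beyond the scatter. Among the compounds with values here, the one single-point step measured so far, an 8.8-fold higher number from compound 1 to compound 3 (0.94 log units; beyond the scatter), shows that lengthening the chain on the aromatic carbon next to the ring nitrogen raises the number well beyond the scatter.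

Compound 4 `CC(=O)c1cccc(C#Cc2cccc(C#N)c2)n1` carries acetyl in place of butyl on an aromatic carbon. Within the data shown here, no measured step covers this exact exchange. Two pieces of evidence bear on it: the ethyl-to-butyl step just noted, which went up, and compound 2, which carries the same acetyl group but also a fluorine on the other ring and gives 240 nM. Shortening the group on that carbon again is expected to bring the number back down, and compound 2 suggests roughly where it should land. Compound 4 is therefore expected to give 200 nM, within a range of 60 nM to 700 nM. The expected step is a 3.5-fold lower number from compound 3 to compound 4 (0.54 log units; beyond the scatter) in this assay.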

Compound 4, half-maximal inhibitory concentration: 300 nM
For compound 4 the middle estimate is 1.5-fold (0.18 log units) below the measured one, and the stated range covers the measured number.
By their numbers in this assay, from the lowest: compound 1; then compounds 2 and 4 (each within the scatter of the next); then compound 3.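

In this assay, acetyl in place of butyl on this aromatic carbon next to the ring nitrogen lowers the number (a 2.3-fold lower number from compound 3 to compound 4 (0.37 log units; beyond the scatter)), while acetyl in place of ethyl raises it (a 3.8-fold higher number from compound 1 to compound 4 (0.57 log units; beyond the scatter)), so acetyl falls inside the span set by the two alkyl groups and does not match ethyl. Hydrogen in place of fluoro, the first exchange seen away from this carbon, stays within the scatter (a 1.3-fold higher number from compound 2 to compound 4 (0.10 log units; within the scatter)), so with acetyl present the fluoro group shows no clear effect on the number. No other kind of data accompanies these numbers, and the steps stand without an explanation.

Going by these compounds, whether propyl would fall on the same trend as ethyl and butyl remains open, as does how an amine or a methyl ester on this carbon would compare with acetyl. Whether fluoro stays without clear effect alongside ethyl or butyl is also unresolved.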